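From propyl to cyclobutyl on the amine nitrogen

This account rests on a few compounds, and the source may have more. Where it says the series, first, only, none or still open, it means among the compounds named here.

Within the data shown here, compound 2 `CCCN(Cc1ccc(OCCn2c(=O)ccn(C)c2=O)c(C)c1)C(CC(=O)O)c1ccc(Cl)cc1` gives 3.2 nm/s in an ADME assay on Caco-2 cells (Homo sapiens) for permeability, read by LC-MS, with a stated time of 2 h (a lower number here means that the compound crosses the layer more slowly, a higher number that the compound crosses the layer faster), and holds the higher of the two numbers so far, ahead of compound 1 `Cc1cc(CN(C)C(CC(=O)O)c2ccc(Cl)cc2)ccc1OCCn1c(=O)ccn(C)c1=O` at 0.6 nm/s by a gap beyond the scatter. Compound 3 `Cc1cc(CN(C2CCC2)C(CC(=O)O)c2ccc(Cl)cc2)ccc1OCCn1c(=O)ccn(C)c1=O` carries one change from compound 2, cyclobutyl in place of propyl on an amine nitrogen, counted as cyclobutyl in place of propyl on an amine nitrogen with the rest of the structure kept.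

Among the measured compounds shown here, one measured step bears on this change: a 5.3-fold higher number from compound 1 to compound 2 (0.73 log units; beyond the scatter) came with ethyl in place of hydrogen on a saturated chain carbon bound to an amine nitrogen, and it was modest but beyond the scatter. For the measured compounds named here, that step added to a chain on this nitrogen, whereas the present change brings a ring, and no measured compound has a ring there. The earlier step therefore gives only weak guidance, and no direction is clearly favoured. The step expected is a 1.1-fold lower number from compound 2 to compound 3 (0.03 log units; within the scatter) and no shift beyond the scatter is anticipated. Compound 3 is estimated at 3 nm/s with an expected range from 1.2 nm/s to 7.5 nm/s for the measurement still to come.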

Compound 3, apparent permeability: 5 nm/s
The estimate for compound 3 lay 1.7-fold (0.22 log units) below the measured number; the range from low to high includes it.
By their numbers in this assay, from the lowest: compound 1; then compounds 2 and 3 (each within the scatter of the next).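

In this assay, cyclobutyl in place of propyl on the amine nitrogen gives a 1.6-fold higher number from compound 2 to compound 3 (0.19 log units; within the scatter), so at this position a group with one four-membered non-aromatic ring of carbon only cannot be told apart from the open propyl chain. The comparison with the methyl group gives an 8.3-fold higher number from compound 1 to compound 3 (0.92 log units; beyond the scatter), which sits alongside a 5.3-fold higher number from compound 1 to compound 2 (0.73 log units; beyond the scatter), so the propyl and cyclobutyl compounds each stand clear of the methyl compound, and none of the three goes against this within the set. Nothing measured on these compounds accounts for either step.

From the compounds shown here alone, what remains open is whether the number stays at this level for other groups on this nitrogen, such as a cyclopropyl or cyclopentyl ring, a longer chain such as butyl or hexyl, or a ring carrying oxygen such as oxetanyl. All three compounds share one core, so these notes cannot say whether the gap from methyl to propyl or cyclobutyl would persist if the carboxylic acid gave way to a primary amide or a tetrazole.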